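Trading 3,5-dimethoxyphenyl for 3,5-dihydroxyphenyl on an ethenyl arm

The compounds below may be only part of what the source reports. "The series", "measured", "known", "first", "only" and "open" are said of these compounds alone.

Of the compounds shown here, two built on a shared core have numbers so far. In a functional assay on MCF7 cells (Homo sapiens) for antiproliferative activity, read by MTT assay, with a stated time of 72 h (a higher number here means a weaker inhibitor, a lower number a stronger inhibitor), compound 1 (`O=S(=O)(Oc1ccc(Cl)cc1)C1CC2OC1C(c1ccc(/C=C/c3cc(O)cc(O)c3)cc1)=C2c1ccc(O)cc1`) gives 17900 nM and compound 2 (`COc1cc(/C=C/c2cccc(OS(=O)(=O)C3CC4OC3C(c3ccc(O)cc3)=C4c3ccc(O)cc3)c2)cc(OC)c1`) gives 11500 nM. These two numbers lie within the usual scatter of repeated measurements, so compound 2 stands level with compound 1 and the pair cannot be ranked.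

Compound 3 (`O=S(=O)(Oc1cccc(/C=C/c2cc(O)cc(O)c2)c1)C1CC2OC1C(c1ccc(O)cc1)=C2c1ccc(O)cc1`) keeps the rest of compound 2 but carries 3,5-dihydroxyphenyl in place of 3,5-dimethoxyphenyl on a double-bonded chain carbon bound to a double-bonded chain carbon. Among the compounds with values here, no measured pair isolates this swap, so its effect in this assay cannot be read directly. Within the data shown here, the only guide is that compound 1, which also carries 3,5-dihydroxyphenyl, gives 17900 nM, and on that basis no step beyond the scatter is expected. The estimated move is a 1.2-fold higher number from compound 2 to compound 3 (0.09 log units; within the scatter), a small one whose direction remains uncertain. For compound 3 the expected value is 14000 nM, with an estimated range from 6000 nM to 32000 nM.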

Compound 3, half-maximal inhibitory concentration: 17800 nM
For compound 3 the middle estimate is 1.3-fold (0.10 log units) below the measured one; the measured number falls inside the stated range.
By their numbers in this assay, from the lowest: compounds 2, 3 and 1 (each within the scatter of the next).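

Within the data shown here, the step of a 1.5-fold higher number from compound 2 to compound 3 (0.19 log units; within the scatter) in this assay is the first direct reading of this swap, because compound 2 and compound 3 differ in this one place only. It shows that 2-(3,5-dimethoxyphenyl)ethenyl and 2-(3,5-dihydroxyphenyl)ethenyl cannot be told apart here, even though the count of hydrogen-bond donors on the group goes from 0 to 2 and the entering group has fewer heavy atoms than the one that leaves. No measurement beyond these antiproliferative numbers is available to account for this result.

The compounds shown leave open whether this place would read differently with a group of another kind on the aromatic ring, such as an amine or a carboxylic acid in place of the two hydroxyl groups. They also leave open what a longer chain in place of the ethenyl link would do, and whether the same swap would read alike with the arm attached as it is in compound 1.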